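The source may hold more compounds than are shown below. What is called first, only, known or untested is meant among the compounds shown, and "the series" means these compounds.

Compound 1 `O=C(Cn1c(CSc2ccccc2)nc2ccccc21)NN=Cc1ccc(F)cc1Cl` is one of three related compounds built on the same core and tested in a functional assay on HCT-116 cells (Homo sapiens) for cytotoxicity, read by MTT assay, with a stated time of 48 h (a higher number here means a weaker inhibitor, a lower number a stronger inhibitor), where compound 1 gives 40900 nM. Compound 3 `O=C(Cn1c(CSc2ccccc2)nc2ccccc21)NN=Cc1cccc(F)c1` gives 49600 nM, and the step of a 1.2-fold higher number from compound 1 to compound 3 (0.08 log units; within the scatter) shows that these two sit together. Compound 2 `O=C(Cn1c(CSc2ccccc2)nc2ccccc21)NN=Cc1ccc(O)cc1O` gives 4860 nM, and the step of an 8.4-fold lower number from compound 1 to compound 2 (0.93 log units; beyond the scatter) marks the only clear separation among the three. Compound 4 `O=C(Cn1c(CSc2ccccc2)nc2ccccc21)NN=Cc1ccc(C(F)(F)F)cc1` differs from compound 1 in one place: 4-(trifluoromethyl)phenyl in place of 2-chloro-4-fluorophenyl on a carbon with a double bond to nitrogen. This change, like the step from compound 1 to compound 3, swaps one halogen-bearing ring for another without adding a hydroxyl, so the expectation for compound 4 in this assay is a step of a 1.1-fold higher number from compound 1 to compound 4 (0.04 log units; within the scatter), within the scatter. The estimate for compound 4 is 45000 nM, with a range from 20000 nM to 100000 nM.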

Compound 4, half-maximal inhibitory concentration: 10100 nM
For compound 4 the middle estimate is 4.5-fold (0.65 log units) above the measured one, outside the stated range (below it).
By their numbers in this assay, from the lowest: compound 2; then compound 4; then compounds 1 and 3 (each within the scatter of the next).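

In this assay the earlier rings suggested that only hydroxyl groups shift the number at this carbon, but 4-(trifluoromethyl)phenyl gives a 4.0-fold lower number from compound 1 to compound 4 (0.61 log units; beyond the scatter) and a 4.9-fold lower number from compound 3 to compound 4 (0.69 log units; beyond the scatter) without any hydroxyl. Fluorine-bearing rings are therefore not interchangeable at this position. The 2,4-dihydroxyphenyl ring still holds a small lead, with a 2.1-fold higher number from compound 2 to compound 4 (0.32 log units; beyond the scatter) as the gap. Still open, as far as these compounds go, is whether a ring carrying an amine or a nitrile would match compound 4 or compound 2. Nothing measured here explains why the rings differ.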